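A few compounds are considered here, and "the series" means these few. Any claim that something is new, unique, unknown or untested is made for them only; others in the source may bear on it.

Of the compounds shown here, three sharing one core have been measured in a functional assay, with a stated time of 20 min, tested at 20 uM; a lower number here means a weaker effect, a higher number a stronger effect of the compound at the concentration tested. Compound 1 `COc1cc(/C=C/C(=O)C2=C(/C=C/c3ccc(O)c(OC)c3)NC(=O)NC2c2c(Cl)cccc2Cl)ccc1O` gives 31.9%. Compound 2 `COc1cc(/C=C/C(=O)C2=C(/C=C/c3ccc(O)c(OC)c3)NC(=S)NC2c2ccc(C)cc2)ccc1O` gives 51%. Compound 3 `COc1cc(/C=C/C(=O)C2=C(/C=C/c3ccc(O)c(OC)c3)NC(=S)NC2c2ccccc2O)ccc1O` gives 72.3%, the highest of the three numbers, with compound 2 nearest and compound 1 furthest. Within the data shown here, the only single-place step among them is a number 21.3 percentage points higher from compound 2 to compound 3 (beyond the scatter), a modest rise beyond the scatter.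

Compound 4 `COc1cc(/C=C/C(=O)C2=C(/C=C/c3ccc(O)c(OC)c3)NC(=S)NC2c2c(Cl)cccc2Cl)ccc1O` is not yet measured. It differs from compound 3 in one place: 2,6-dichlorophenyl in place of 2-hydroxyphenyl on a saturated ring carbon.

This change undoes the kind of move that helped in the step from compound 2 to compound 3, since the 2-hydroxyphenyl that arrived there now leaves. Compound 1 carries the same 2,6-dichlorophenyl as compound 4 but differs from compound 3 in two places rather than one, so no single step can be read from it. The value of compound 1, 31.9%, is simply the lowest seen. On this basis compound 4 is expected to fall below compound 3, with an estimated step of a number 30.3 percentage points lower from compound 3 to compound 4 (beyond the scatter) in this assay. The estimate for compound 4 is 42%, within a range from 27% to 58%.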

Compound 4, a percentage reported as activity, at one concentration (the size of the read-out at that concentration, not a potency): 43.2%
Compound 4: middle estimate off by 1.2 percentage points, on the low side; measured number inside the range.
By their numbers in this assay, from the lowest: compound 1; then compounds 4 and 2 (each within the scatter of the next); then compound 3.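

In this assay, the step of a number 29.1 percentage points lower from compound 3 to compound 4 (beyond the scatter) shows that this saturated ring carbon is sensitive to exchanging 2-hydroxyphenyl for 2,6-dichlorophenyl, giving this position a second change that is larger than the scatter. The step of a number 7.8 percentage points lower from compound 2 to compound 4 (within the scatter) adds something new: 2,6-dichlorophenyl and 4-methylphenyl cannot be told apart here, even though they are substituted differently, so among these three groups with the thiocarbonyl core, only 2-hydroxyphenyl stands apart. The 2-hydroxyphenyl group counts 1 hydrogen-bond donor and 1 hydrogen-bond acceptor where 2,6-dichlorophenyl counts none, but no measurement here explains the difference in read-out.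

The compounds shown leave open whether the higher number belongs to the hydroxyl group itself or depends on where it sits on the phenyl ring. Unsubstituted phenyl, 2-methoxyphenyl, 4-hydroxyphenyl and 2-aminophenyl at this same carbon would separate these possibilities, and would show whether the level shared by compound 2 and compound 4 is simply what a phenyl ring without a hydroxyl group gives.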